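The source may hold more compounds than are shown below. What is called first, only, known or untested is meant among the compounds shown, and "the series" means these compounds.

Compound 1 `COc1ccc(F)cc1CNCCCNc1ccnc2cc(Cc3ccc(C#N)cc3)ccc12`: 9.47
Compound 2 `COc1ccc(F)cc1CNCCCNc1ccnc2cc(Cc3cccc(C(F)(F)F)c3)ccc12`: 9.47
Compound 3 `N#Cc1ccc(Cc2ccc3c(NCCCNCc4ccco4)ccnc3c2)cc1`: 9.47

These three compounds were measured in a physicochemical assay for acid dissociation. Compound 1 and compound 2 differ in one place: 3-(trifluoromethyl)phenyl in place of 4-cyanophenyl on a saturated chain carbon bound to an aromatic carbon. The step that goes with it is no change at the digits printed from compound 1 to compound 2 (within the scatter). Compound 1 and compound 3 differ at the other end of the chain: furan-2-yl in place of 5-fluoro-2-methoxyphenyl on a saturated chain carbon bound to an amine nitrogen. Here too the step is no change at the digits printed from compound 1 to compound 3 (within the scatter). Compound 3 thus stands level with compound 1 and compound 2 at the digits given.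

The unmeasured compound 4 `FC(F)(F)c1cccc(Cc2ccc3c(NCCCNCc4ccco4)ccnc3c2)c1` is related to compound 3 by 3-(trifluoromethyl)phenyl in place of 4-cyanophenyl on a saturated chain carbon bound to an aromatic carbon. For the measured compounds named here, this is the same change as the one from compound 1 to compound 2, made at the same place, on a core that differs from that of compound 1 as described by the difference between compound 1 and compound 3. Because the earlier step was no change at the digits printed from compound 1 to compound 2 (within the scatter), the step from compound 3 to compound 4 is expected to be no change at the digits printed from compound 3 to compound 4 (within the scatter). Compound 4 is therefore estimated to give 9.47 in this assay, with a range from 9.2 to 9.75.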

Compound 4, acid dissociation constant: 9.47
For compound 4 middle estimate and measured number coincide at the digits printed, within the range that was stated.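

In this assay, putting 3-(trifluoromethyl)phenyl in place of 4-cyanophenyl gave no change at the digits printed from compound 3 to compound 4 (within the scatter), the same outcome as no change at the digits printed from compound 1 to compound 2 (within the scatter), so the change carried from the core of compound 1 to the core of compound 3 with no difference between the two steps. The square closes in the same way at the other end of the chain, where furan-2-yl in place of 5-fluoro-2-methoxyphenyl gave no change at the digits printed from compound 2 to compound 4 (within the scatter). All four compounds stand level, however, so agreement between two steps without any change shows neither how a step of real size would carry over nor how this change would behave on any other core.

Nothing given here bears on why the values stand level. The compounds shown leave open whether a longer chain, or a carboxylic acid or an amine in place of the groups exchanged here, would move the reading in this assay.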